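Changing the oxygen-linked group of compound 3

The compounds below may be only part of what the source reports. "The series", "measured", "known", "first", "only" and "open" are said of these compounds alone.

In a physicochemical assay for solubility, read by HPLC, in phosphate buffer, at pH 6.5 (on this read-out higher numbers stand for higher solubility and lower numbers for lower solubility), three compounds sharing one core have been measured. Compound 1 `COC(=O)C1=C(CN2CCCCC2)NC(c2nccs2)=NC1(C)c1ccc(F)cc1` gives 282 ug/mL. Compound 2 `COC(=O)C1=C(CN(C)C2(C(=O)O)CC2)NC(c2nccs2)=NC1(C)c1ccc(F)cc1` gives > 510 ug/mL, which is a limit of the assay and not a number. Within the data shown here, compound 3 `COC(=O)C1=C(COC2CCOC2)NC(c2nccs2)=NC1(C)c1ccc(F)cc1` gives 30 ug/mL, the lowest of the numbers so far. The measured steps that reach it are a 9.4-fold lower number from compound 1 to compound 3 (0.97 log units; beyond the scatter) and an at least 17-fold lower number from compound 2 to compound 3 (1.23 log units; beyond the scatter).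

Compound 4 `COC(=O)C1=C(COCC(F)(F)F)NC(c2nccs2)=NC1(C)c1ccc(F)cc1` differs from compound 3 in one group: 2,2,2-trifluoroethyl in place of oxolan-3-yl on an oxygen on a saturated carbon. In words, 2,2,2-trifluoroethyl stands in place of oxolan-3-yl on an oxygen on a saturated carbon. Both measured steps bear on this only indirectly, since each brings in the (oxolan-3-yl)oxy group in place of a nitrogen-linked group. Neither exchanges one oxygen-linked group for another, so their size does not carry over. Only a modest downward change is therefore expected in this assay. The expected step is a 2.1-fold lower number from compound 3 to compound 4 (0.33 log units; beyond the scatter). Compound 4 is estimated at 14 ug/mL, with an expected range from 5 ug/mL to 40 ug/mL.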

Compound 4, solubility: 19 ug/mL
Compound 4: middle estimate off by 1.4-fold (0.13 log units), on the low side; low and high end bracket the measured number.
By their numbers in this assay, from the lowest: compounds 4 and 3 (each within the scatter of the next); then compound 1. At a limit, above all of these: compound 2.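

Among these compounds, exchanging one oxygen-linked group for another, the change the earlier compounds did not cover, gives a 1.6-fold lower number from compound 3 to compound 4 (0.20 log units; within the scatter) in this assay, so oxolan-3-yl and 2,2,2-trifluoroethyl on this oxygen are not told apart, even though the ring and its hetero atom leave. The exchange of piperidin-1-yl for 2,2,2-trifluoroethoxy gives a 15-fold lower number from compound 1 to compound 4 (1.17 log units; beyond the scatter), so a second oxygen-linked group, one without a ring, also stands well under compound 1. Compound 2 gives > 510 ug/mL, which is a limit of the assay and not a number, and an at least 26-fold lower number from compound 2 to compound 4 (1.42 log units; beyond the scatter) is read against that limit: the limit of > 510 ug/mL in this assay, at which 1 of the 4 values shown sits.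

The compounds shown leave open how an amine or a carboxylic acid carried on the oxygen-linked group would read. They also leave open whether a longer chain on that oxygen would stay level with compound 3 and compound 4.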